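Stereochemical variation in a glycosyl-derived somatostatin receptor series

The compounds below may be only part of what the source reports. "The series", "measured", "known", "first", "only" and "open" are said of these compounds alone.

Measured compounds:
- compound 1, `CS[C@@H]1O[C@H](COCc2ccc(Cl)cc2)[C@@H](O)[C@@H](OCc2ccc3ccccc3c2)[C@H]1NC(=O)CCN`, 6330 nM in an assay on CHO cells for displacement of a labelled ligand from somatostatin receptor type 3 (Homo sapiens); on this read-out higher numbers stand for weaker inhibition and lower numbers for stronger inhibition
- compound 2, `COC[C@H]1O[C@H](OCCc2ccccc2)[C@H](NC(=O)CCCN)[C@H](OCc2ccc3ccccc3c2)[C@@H]1O`, 8400 nM

In this assay compound 2 has the highest number of the two; compound 1 lies nearest, and the gap between compound 2 and compound 1 is within the scatter. Compound 3, `COC[C@H]1O[C@@H](OCCc2ccccc2)[C@H](NC(=O)CCCN)[C@@H](OCc2ccc3ccccc3c2)[C@@H]1O`, keeps every atom and bond of compound 2: the two compounds have the same atoms and bonds and differ only in configuration as drawn: 2 of 5 stereo elements differ; a stereocentre at a saturated ring carbon is drawn S in compound 2 and R in compound 3; a stereocentre at a saturated ring carbon is drawn S in compound 2 and R in compound 3. Going by the values given here, no measured pair in the set differs by configuration alone, so the size of this step is not backed by data. A change in either direction is possible, but with compound 2 already weak in this assay the expectation is a step of roughly a 1.1-fold higher number from compound 2 to compound 3 (0.03 log units; within the scatter), not beyond the scatter. Compound 3 is thus estimated at 9000 nM, within 2500 nM to 30000 nM.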

Compound 3, half-maximal inhibitory concentration: 1320 nM
Compound 3: the middle estimate sits 6.8-fold (0.83 log units) above what was measured; measured number below the stated range.
By their numbers in this assay, from the lowest: compound 3; then compounds 1 and 2 (each within the scatter of the next).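

In this assay configuration alone moves the number, and the change at two saturated ring carbons gives a 6.4-fold lower number from compound 2 to compound 3 (0.80 log units; beyond the scatter) in this pair. Going by these compounds alone, the earlier compounds offered no pair of this kind, so this is the first sign that these stereocentres matter with atoms and bonds held fixed. The step can be assigned to configuration because nothing else changes: the fact that compounds 2 and 3 differ only in the configuration as drawn

Which of the two stereocentres carries the step stays open, since both change together. Also open, going by these compounds, is whether the same change pays with a guanidine in place of the side-chain amine.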